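A few compounds are considered here, and "the series" means these few. Any claim that something is new, unique, unknown or untested is made for them only; others in the source may bear on it.

Measured compounds:
compound 1, `Cc1ccc(C2(CNC(=O)Nc3c(C(C)C)cccc3C(C)C)CCCC2)cc1`: 25 nM
compound 2, `CC(C)c1cccc(C(C)C)c1NC(=O)NCC1(c2ccc(C(C)(C)C)cc2)CCCC1`: 63 nM
compound 3, `CC(C)c1cccc(C(C)C)c1NC(=O)NCC1(c2ccc(F)cc2)CCCC1`: 23 nM

All numbers come from an assay on microsomes for inhibition of acyl-CoA:cholesterol acyltransferase (Oryctolagus cuniculus); a lower number here means a stronger inhibitor, a higher number a weaker inhibitor. Compound 3 holds the lowest of the measured numbers. The step of a 1.1-fold lower number from compound 1 to compound 3 (0.04 log units; within the scatter) is within the scatter, so no order between these two compounds can be claimed; the step of a 2.7-fold lower number from compound 2 to compound 3 (0.44 log units; beyond the scatter) is beyond it, and compound 2 is the furthest away.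

Compound 4, `CC(C)c1cccc(C(C)C)c1NC(=O)NCC1(c2ccccc2C(F)(F)F)CCCC1`, is not yet measured. Its change from compound 3 is 2-(trifluoromethyl)phenyl in place of 4-fluorophenyl on a saturated ring carbon. The measured steps that bear on it are all exchanges of one group on an aromatic carbon of this aryl unit: a 2.5-fold higher number from compound 1 to compound 2 (0.40 log units; beyond the scatter) and a 2.7-fold lower number from compound 2 to compound 3 (0.44 log units; beyond the scatter) show tert-butyl giving a modestly higher number than methyl or fluoro, while a 1.1-fold lower number from compound 1 to compound 3 (0.04 log units; within the scatter) shows methyl and fluoro interchangeable. None of them exchanges fluoro for trifluoromethyl or replaces the aryl unit as a whole, so the precedent is indirect. Within the data shown here, a trifluoromethyl is larger than fluoro, and the only larger group tried, tert-butyl, gave a higher number; a modest rise is therefore expected, a 2.2-fold higher number from compound 3 to compound 4 (0.34 log units; beyond the scatter), with wide uncertainty.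

Compound 4 is estimated at 50 nM, with a range from 18 nM to 160 nM.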

Compound 4, half-maximal inhibitory concentration: 18 nM
Beside the measured number, compound 4's estimate is 2.8-fold (0.44 log units) above it; measured number inside the range.
By their numbers in this assay, from the lowest: compounds 4, 3 and 1 (each within the scatter of the next); then compound 2.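

In this assay, the aryl unit on the saturated ring carbon accepts a larger change than the single-group exchanges showed: a 1.3-fold lower number from compound 3 to compound 4 (0.11 log units; within the scatter) and a 1.4-fold lower number from compound 1 to compound 4 (0.14 log units; within the scatter) both lie within the scatter, so 2-(trifluoromethyl)phenyl cannot be ordered against 4-fluorophenyl or 4-methylphenyl. Against 4-(tert-butyl)phenyl, a 3.5-fold lower number from compound 2 to compound 4 (0.54 log units; beyond the scatter) is beyond the scatter, so compound 2 remains the only compound set apart, and the step from 4-fluorophenyl to 2-(trifluoromethyl)phenyl, which has more heavy atoms, brings no measurable rise, which means group size alone does not order these four compounds. Nothing measured on these compounds explains the result.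

The compounds shown cannot separate the effect of the group from that of its place on the phenyl, a question that 4-(trifluoromethyl)phenyl and 2-fluorophenyl would address. Also open, on these data alone, is how this position responds to an amine or a carboxylic acid on the phenyl, or to a pyridine in place of the phenyl.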